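The compounds below may be only part of what the source reports. "The series", "measured", "known", "first", "only" and "open" are said of these compounds alone.

Measured so far:
- compound 1 `CCCCOC1=CC(=O)c2ccccc2C1=O`: 35300 nM
- compound 2 `O=C1C=CC(=O)c2cc(OCc3ccccc3)ccc21`: 16800 nM
- compound 3 `CCOc1ccc2c(c1)C(=O)C=CC2=O`: 25100 nM

All three numbers come from a functional assay on HeLa cells (Homo sapiens) for cytotoxicity; a lower number here means a stronger inhibitor, a higher number a weaker inhibitor. The number of compound 3 is the middle one of the three, but it lies within the scatter of each of the other two, so no order is claimed around it.

The next compound is compound 4 `O=C1C=CC(=O)c2cc(Oc3ccco3)ccc21`, with furan-2-yl in place of ethyl on an oxygen on an aromatic ring.

For the measured compounds named here, only one measured step bears on this change: a 1.5-fold higher number from compound 2 to compound 3 (0.17 log units; within the scatter). It exchanges phenyl for methyl on a saturated chain carbon bound to an oxygen on an aromatic ring, so a sizeable change in that substituent has so far left this assay within the scatter. Going by the values given here, compound 1 enters no measured step. Among the compounds with values here, no measured compound carries an aromatic ring on that oxygen itself, so this is an extrapolation from a single step and the range is kept wide.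

No step beyond the scatter is expected, and the estimated step is a 1.3-fold lower number from compound 3 to compound 4 (0.10 log units; within the scatter). For compound 4 the expected value is 20000 nM, with an estimated range of 8000 nM to 45000 nM.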

Compound 4, half-maximal inhibitory concentration: 17200 nM
Compound 4: the middle estimate sits 1.2-fold (0.07 log units) above what was measured; low and high end bracket the measured number.
By their numbers in this assay, from the lowest: compounds 2, 4, 3 and 1 (each within the scatter of the next, the first and the last beyond it).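

Working notes on the oxygen on an aromatic ring: in this assay, furan-2-yl in place of ethyl gives a step (a 1.5-fold lower number from compound 3 to compound 4 (0.16 log units; within the scatter)), so the first aromatic ring set directly on that oxygen leaves the number within the scatter. This matches the earlier exchange of phenyl for methyl on the saturated chain carbon bound to that oxygen (a 1.5-fold higher number from compound 2 to compound 3 (0.17 log units; within the scatter)), which also stayed within the scatter, so neither of the two steps at this position has shifted the number beyond it. The entering group also brings a five-membered aromatic ring and a hydrogen-bond acceptor, and in this single step that combination does not separate compound 4 from compound 3, while no evidence on hand bears on why the number holds so steady.

From the compounds shown here alone, it remains open whether any group on this oxygen can move the number beyond the scatter, for instance an amine or a carboxylic acid carried on a longer chain. For the compounds shown here, compound 1 enters no step with the others, so the gap between its number and that of compound 2 cannot be assigned to any single change.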